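The source may report more compounds than this note shows. Statements on the series, on what has been measured and on what is new or still open speak of the compounds shown alone.

Measured so far:
Compound 1 `CN1CCN(CCNCc2cn(-c3ccc(F)cc3F)nc2-c2cccc(Cl)c2)CC1`: 15000 nM
Compound 2 `CSc1ccc(-n2cc(CNCCN3CCN(C)CC3)c(-c3ccccc3C)n2)cc1`: 17000 nM

In an ADME assay on Huh-7 cells (Homo sapiens) for cytotoxicity (a lower number here means that less compound is tolerated, a higher number that more compound is tolerated), compound 1 gives 15000 nM. On the two numbers shown, compound 1 has the lowest value, and its nearest neighbour is compound 2, which gives 17000 nM in this assay, a gap that lies within the scatter, so the two compounds cannot be ordered against each other. Compound 3 `COC(=O)c1ccc(-c2nn(-c3ccc(F)cc3F)cc2CNCCN2CCN(C)CC2)cc1` has not yet been measured. It differs from compound 1 in one place: 4-(methoxycarbonyl)phenyl in place of 3-chlorophenyl on an aromatic carbon. Going by the values given here, no step between two measured compounds describes this kind of change, so no measured step can anchor it. Given that the two measured values sit close together, and that both compounds share the core of compound 1 with its basic side chain, the expectation is that compound 3 will land within the scatter of compound 1, with a step of a 1.2-fold higher number from compound 1 to compound 3 (0.08 log units; within the scatter) that is expected to be small in either direction. Compound 3 is accordingly expected to give about 18000 nM in this assay, with a likely range from 8000 nM to 45000 nM.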

Compound 3, half-maximal cytotoxic concentration: > 20000 nM
Compound 3 gave a limit, no number; the forecaster's own chance of this, stated with the estimate: 20%; at least 1.1-fold (0.04 log units) between middle value and limit.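

Going by these compounds alone, compound 3 gives the first reading for a change at this position, on an aromatic carbon of a five-membered aromatic ring with 2 nitrogen, where 3-chlorophenyl gives way to 4-(methoxycarbonyl)phenyl. In this assay, the replacement brings an at least 1.3-fold higher number from compound 1 to compound 3 (0.12 log units; that floor lies within the scatter), so the larger group, with its 2 hydrogen-bond acceptors, does not bring a lower number than 3-chlorophenyl on this reading. Compound 3 gives a limit and not a number, so the size of the step remains unknown and it may or may not exceed the scatter: the limit of > 20000 nM in this assay, at which 1 of the 3 values shown sits.

The change moves the ring substituent, removes the chlorine and adds the methyl ester in one step, so the two compounds cannot show which of these matters, and 4-chlorophenyl or unsubstituted phenyl at this position would be needed to separate them. The compounds shown also leave open how a carboxylic acid or a primary amide in place of the methyl ester would read in this assay.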